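The source may report more compounds than this note shows. Statements on the series, on what has been measured and on what is new or still open speak of the compounds shown alone.

Measured so far:
- compound 1, `Nc1cc(N)c2nc(-c3ccccc3)c(Oc3ccc(Cl)c(Cl)c3)nc2c1`: 16200 nM
- compound 2, `COc1ccc(CNc2nc3cc(N)cc(N)c3nc2-c2ccccc2)cc1OC`: 12900 nM

Both compounds were tested in a functional assay on UACC-62 cells (Homo sapiens) for inhibition, read by sulforhodamine B assay, with a stated time of 48 h; on this read-out higher numbers stand for weaker inhibition of growth and lower numbers for stronger inhibition of growth. In this assay compound 1 gives 16200 nM, and compound 2 gives 12900 nM. These two numbers lie within the scatter of repeated measurements of one another, so compound 1 cannot be set apart from compound 2 on the evidence at hand; both stand in the same weak range.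

Compound 3, `Nc1cc(N)c2nc(-c3ccccc3)c(Sc3ccc(F)cc3)nc2c1`, has not yet been measured. It differs from compound 1 in one place: (4-fluorophenyl)sulfanyl in place of 3,4-dichlorophenoxy on an aromatic carbon. The (4-fluorophenyl)sulfanyl group sits where the 3,4-dichlorophenoxy group sat, on an aromatic carbon of a six-membered aromatic ring with two nitrogens, part of a fused system of two rings, next to the ring nitrogen and ortho to a phenyl group.

Among the compounds with values here, no step between two measured compounds is available to calibrate this change. With both measured compounds sitting close together in this assay, no movement beyond the scatter is expected, so the step from compound 1 to compound 3 is estimated as a 1.2-fold lower number from compound 1 to compound 3 (0.10 log units; within the scatter). Compound 3 is therefore expected to give about 13000 nM in this assay, within a range from 4000 nM to 40000 nM.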

Compound 3, concentration for 50% growth inhibition: 16600 nM
The estimate for compound 3 lay 1.3-fold (0.11 log units) below the measured number; low and high end bracket the measured number.
By their numbers in this assay, from the lowest: compounds 2, 1 and 3 (each within the scatter of the next).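

In this assay, putting (4-fluorophenyl)sulfanyl in place of 3,4-dichlorophenoxy on this aromatic carbon, ortho to a phenyl group, gives a 1.0-fold higher number from compound 1 to compound 3 (0.01 log units; within the scatter). Within the data shown here, this is the first direct one-place comparison at this position, and it shows that the group there can be exchanged without a shift beyond the scatter, even though the linking oxygen gives way to sulfur and chlorine gives way to fluorine at the same time. Because both features change in a single step, this result cannot show what either one does alone, and no measurement of any property of these groups is at hand to interpret the result.

The compounds shown leave open whether the link and the ring substituents each have no effect of their own, or whether separate effects happen to cancel here. They also leave open whether a group of a different kind at this position, such as a carboxylic acid or a morpholine, would move the number beyond the scatter in this assay.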